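The source may report more compounds than this note shows. Statements on the series, on what has been measured and on what is new or still open speak of the compounds shown alone.

Compound 1 `COc1cc(COc2cc(N)c(Cl)cc2C(=O)CCCCN2CCCCC2)cc(OC)c1` is the reference point of this small series. In a functional assay for antagonist activity at 5-hydroxytryptamine receptor 4 (Rattus norvegicus) (a lower number here means a less potent compound, a higher number a more potent compound, by a factor of ten per unit of this negative logarithm), compound 1 gives 8.5. Two companions carry a substituent on a saturated ring carbon of the same core: compound 2 `COc1cc(COc2cc(N)c(Cl)cc2C(=O)CCCCN2CCC(C)CC2)cc(OC)c1` gives 8.3 and compound 3 `COc1cc(COc2cc(N)c(Cl)cc2C(=O)CCCCN2CCC(O)CC2)cc(OC)c1` gives 8.3. Compound 1 holds the highest of the three numbers, but the step of a number 0.20 log units lower from compound 1 to compound 2 (within the scatter) and the step of a number 0.20 log units lower from compound 1 to compound 3 (within the scatter) both fall within the scatter, as does no change at the digits printed from compound 2 to compound 3 (within the scatter), so the three compounds cannot be told apart on these data.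

The question is compound 4 `COc1cc(COc2cc(N)c(Cl)cc2C(=O)CCCCN2CCC(CCNS(C)(=O)=O)CC2)cc(OC)c1`. It differs from compound 1 by 2-(methanesulfonamido)ethyl in place of hydrogen on a saturated ring carbon. Going by the values given here, the two measured steps at this ring position, methyl and hydroxy in place of hydrogen, are the only guide, and each stayed within the scatter. Among the compounds with values here, the entering group here is much larger, and no measured compound shows what a group of this size does at that position, so the guide is loose. Compound 4 is therefore expected to sit near compound 1, with a step of a number 0.30 log units lower from compound 1 to compound 4 (within the scatter) and a wide band. The estimate for compound 4 is 8.2, ranging from 7.3 to 8.9.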

Compound 4, negative logarithm of the antagonist equilibrium constant: 8.1
Estimate against measurement, compound 4: 0.10 log units above; the range from low to high includes it.
By their numbers in this assay, from the lowest: compounds 4, 2, 3 and 1 (each within the scatter of the next, the first and the last beyond it).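

Going by these compounds alone, the step of a number 0.40 log units lower from compound 1 to compound 4 (beyond the scatter) is the first at this ring position to pass beyond the scatter in this assay, though it remains modest, and methyl and hydroxy gave no such separation from compound 1. Even so, 2-(methanesulfonamido)ethyl, a much larger entering group with no ring and no net charge, leaves compound 4 at 8.1 and so keeps the antagonist read-out high on the scale of this small series. The separation reaches only compound 1, since the step of a number 0.20 log units lower from compound 3 to compound 4 (within the scatter) and the step of a number 0.20 log units lower from compound 2 to compound 4 (within the scatter) both stay within the scatter, and the three substituted compounds therefore form no order among themselves; nothing available bears on why the read-out shifts at this position.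

As far as these compounds go, it remains open whether the modest step belongs to the length of the chain or to its methanesulfonamide end, a question that a plain butyl chain of similar reach could address. Also open, from the compounds shown here alone, is how a chain ending in an amine or a carboxylic acid would read at this ring carbon, and whether a still longer chain would widen the step from compound 1.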